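Replacing a Methyl Ester with an Acetoxymethyl Group

This account rests on a few compounds, and the source may have more. Where it says the series, first, only, none or still open, it means among the compounds named here.

Measured compounds:
compound 1 `CCc1cccc2c(O)c(-c3occ(C)c3C(=O)O)ccc12`: 8.7 ug/mL
compound 2 `CCc1cccc2c(OC)c(-c3occ(C)c3C(=O)OC)ccc12`: 2.2 ug/mL
compound 3 `CCc1cccc2c(OC)c(-c3occ(C)c3CBr)ccc12`: > 10 ug/mL

In a functional assay on DU-145 cells (Homo sapiens) for cytotoxicity, read by MTT assay, with a stated time of 72 h (on this read-out higher numbers stand for an effect only at larger amounts of compound and lower numbers for an effect already at smaller amounts), compound 2 gives 2.2 ug/mL, the lowest of the two numbers obtained, while compound 1 gives 8.7 ug/mL. For compound 3 this assay reports only a limit, > 10 ug/mL, which is the limit of > 10 ug/mL in this assay, at which 1 of the 3 values shown sits. For the measured compounds named here, the one measured step that touches the same position is an at least 4.5-fold higher number from compound 2 to compound 3 (0.65 log units; beyond the scatter). Compound 4 `CCc1cccc2c(OC)c(-c3occ(C)c3COC(C)=O)ccc12` differs from compound 2 by acetoxymethyl in place of methoxycarbonyl on an aromatic carbon. Since that step removed the methoxycarbonyl and the number rose, a rise is expected here too, though the acetoxymethyl keeps an ester and the rise is expected to be smaller: a 2.3-fold higher number from compound 2 to compound 4 (0.36 log units; beyond the scatter). Compound 4 is therefore estimated at 5 ug/mL, with a range from 2 ug/mL to 12 ug/mL.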

Compound 4, concentration for half-maximal effect: > 10 ug/mL
Compound 4 ended at the assay's limit (the forecaster's own chance of this, stated with the estimate: 25%); at least 2.0-fold (0.30 log units) between middle value and limit.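

In this assay, acetoxymethyl in place of methoxycarbonyl gives an at least 4.5-fold higher number from compound 2 to compound 4 (0.65 log units; beyond the scatter). At this position, then, keeping an ester in the substituent, with the same count of hydrogen-bond acceptors, does not preserve the lower number of compound 2. Compound 3 and compound 4 each give only a limit, so the step between them cannot be read and bromomethyl cannot be ranked against acetoxymethyl: the limit of > 10 ug/mL in this assay, at which 2 of the 4 values shown sit.

The compounds shown leave open whether an amide or an aminomethyl group at this position would keep the lower number. On these data alone, how far the true values of compound 3 and compound 4 lie beyond their limits also remains open.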